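A few compounds are considered here, and "the series" means these few. Any claim that something is new, unique, unknown or untested is made for them only; others in the source may bear on it.

Measured so far:
compound 1 `COC(=O)Nc1cccc(-c2ccc(N(C)C)cc2)c1` gives 5000 nM; compound 2 `CCOC(=O)Nc1cccc(-c2ccc(N(C)C)cc2)c1` gives 3000 nM; compound 3 `CC(C)OC(=O)Nc1cccc(-c2ccc(N(C)C)cc2)c1` gives 82000 nM, all in an assay on COS-7 cells for inhibition of patatin-like phospholipase domain-containing protein 2 (Mus musculus); a higher number here means a weaker inhibitor, a lower number a stronger inhibitor.

Compound 3 stands highest of the three numbers: the step of a 16-fold higher number from compound 1 to compound 3 (1.21 log units; beyond the scatter) and the step of a 27-fold higher number from compound 2 to compound 3 (1.44 log units; beyond the scatter) both lie beyond the scatter, whereas a 1.7-fold lower number from compound 1 to compound 2 (0.22 log units; within the scatter) does not. Compound 4 `CN(C)c1ccc(-c2cccc(NC(=O)Oc3ccccc3)c2)cc1` differs from compound 3 by phenyl in place of isopropyl on an oxygen next to a carbonyl group. The two steps that bear on this place, from compound 1 and from compound 2 to compound 3, show that isopropyl on this oxygen raised the number strongly; phenyl has not been tried there, so the direction is uncertain. The writer expects compound 4 to fall somewhat between, with a 10-fold lower number from compound 3 to compound 4 (1.01 log units; beyond the scatter) as the expected step, giving an estimate of 8000 nM (range 1500 nM to 40000 nM).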

Compound 4, half-maximal inhibitory concentration: 73000 nM
Estimate against measurement, compound 4: 9.1-fold (0.96 log units) below; measured number above the stated range.
By their numbers in this assay, from the lowest: compounds 2 and 1 (each within the scatter of the next); then compounds 4 and 3 (each within the scatter of the next).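

In this assay, phenyl on this oxygen reads the same as isopropyl, with a 1.1-fold lower number from compound 3 to compound 4 (0.05 log units; within the scatter), so the high number is not confined to isopropyl. The loss against the smaller groups is large both for ethyl, with a 24-fold higher number from compound 2 to compound 4 (1.39 log units; beyond the scatter), and for methyl, with a 15-fold higher number from compound 1 to compound 4 (1.16 log units; beyond the scatter), and compound 4 and compound 3 sit together apart from compound 1 and compound 2. Nothing available accounts for this shared loss. Going by these compounds, whether a straight propyl chain or a benzyl group on this oxygen would stay with methyl and ethyl or join isopropyl and phenyl remains open.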